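Working notes: from compound 1 to compound 4

This account rests on a few compounds, and the source may have more. Where it says the series, first, only, none or still open, it means among the compounds named here.

Of the compounds shown here, three have so far been tested in a functional assay on A-375 cells (Homo sapiens) for antiproliferative activity, read by CCK-8 assay, with a stated time of 72 h, tested at 2 uM; a higher number here means a stronger effect of the compound at the concentration tested, a lower number a weaker effect. Compound 1 `Nc1ccccc1NC(=O)c1ccc(CSC(=S)N2CCN(Cc3ccccn3)CC2)cc1` gives 20.7% in this assay, the lowest of the three numbers shown. Compound 2 `Nc1ccccc1NC(=O)c1ccc(CSC(=S)N2CCc3ccc([N+](=O)[O-])cc32)cc1` gives 22.1% in this assay, a number close to that of compound 1 and within the usual scatter, so the two cannot be separated. Compound 3 `CN(Cc1ccncc1)C(=S)SCc1ccc(C(=O)Nc2ccccc2N)cc1` gives 31.4% in this assay, which lies beyond the scatter above compound 1 and is the furthest of the three from it. Among the compounds with values here, no pair among the measured compounds differs in only one place, so no single structural step has a measured size in this set.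

Compound 4 `Nc1ccccc1NC(=O)c1ccc(CSC(=S)N2CCN(c3ccccc3)CC2)cc1` has not yet been measured. It differs from compound 1 as follows: phenyl in place of (pyridin-2-yl)methyl on an amine nitrogen in a ring. Nothing measured in the series bears on a change at this ring nitrogen, and the three known values fall in a narrow band. The step of a number 1.3 percentage points higher from compound 1 to compound 4 (within the scatter) is therefore expected to be small, with no direction claimed, and not beyond the scatter. Compound 4 is expected to give about 22% in this assay, within a range from 10% to 35%.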

Compound 4, a percentage reported as inhibition, at one concentration (the size of the read-out at that concentration, not a potency): 27.5%
The estimate for compound 4 lay 5.5 percentage points below the measured number, and the stated range covers the measured number.
By their numbers in this assay, from the lowest: compounds 1, 2, 4 and 3 (each within the scatter of the next, the first and the last beyond it).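

Within the data shown here, the first change in a single place reads in this assay as a number 6.8 percentage points higher from compound 1 to compound 4 (within the scatter) and so cannot be told from no change, which means that phenyl in place of (pyridin-2-yl)methyl on this amine nitrogen in a ring has no measurable effect for this pair. The group that leaves carries a hydrogen-bond acceptor and a hetero atom in its aromatic ring, while the group that enters carries neither, and that difference comes with no step beyond the scatter, so this pair shows no need for either feature at this position. Nothing measured here accounts for the size of this step.

Still open, on these data alone, is whether a group of another kind on the same ring nitrogen, such as a methyl, a carboxylic acid or a longer chain ending in an amine, would move the number beyond the scatter. As far as these compounds go, the read-out at a single concentration gives the size of the effect and not a potency, so any difference in potency between these two compounds also stays open.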